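Replacing the 4-bromophenyl group of compound 1

This account rests on a few compounds, and the source may have more. Where it says the series, first, only, none or still open, it means among the compounds named here.

Measured in a functional assay on DU-145 cells (Homo sapiens) for inhibition, read by trypan blue exclusion, with a stated time of 96 h (a higher number here means a weaker inhibitor of growth, a lower number a stronger inhibitor of growth), so far:
- Compound 1 `O=C(O)c1ccc(C(=O)/C(=C\c2ccc(Br)cc2)SCc2ccc(F)cc2)cc1` gives > 100000 nM as a limit, not a number
- Compound 2 `O=C(/C(=C\c1ccc(Br)cc1)SCc1ccc(F)cc1)c1ccc(Cl)cc1` gives 9000 nM as a number
- Compound 3 `O=C(O)c1ccc(C(=O)/C(=C\c2ccc(Br)cc2)SCc2ccc(Br)cc2)cc1` gives 1000 nM as a number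

Compound 1 is the weakest of the three, and its reading is only a limit (the limit of > 100000 nM in this assay, at which 1 of the 3 values shown sits). Compound 4 `Nc1ccc(/C=C(/SCc2ccc(F)cc2)C(=O)c2ccc(C(=O)O)cc2)cc1[N+](=O)[O-]` carries 4-amino-3-nitrophenyl in place of 4-bromophenyl on a double-bonded chain carbon bound to a double-bonded chain carbon. Neither measured step touches that place. Chloro in place of carboxy gave an at least 11-fold lower number from compound 1 to compound 2 (1.04 log units; beyond the scatter) and bromo in place of fluoro gave an at least 100-fold lower number from compound 1 to compound 3 (2.00 log units; beyond the scatter) as large steps elsewhere on the molecule. Among the compounds with values here, they show only that a change can pull compound 1 well down, so they guide the new step loosely. The expected step in this assay is a moderate drop, estimated as an at least 4.0-fold lower number from compound 1 to compound 4 (0.60 log units; beyond the scatter) with wide uncertainty. For compound 4 the estimated value is 25000 nM (range 4000 nM to 100000 nM).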

Compound 4, concentration for 50% growth inhibition: 10000 nM
Compound 4: middle estimate off by 2.5-fold (0.40 log units), on the high side; the measured number falls inside the stated range.
By their numbers in this assay, from the lowest: compound 3; then compounds 2 and 4 (each within the scatter of the next). At a limit, above all of these: compound 1.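

Putting 4-amino-3-nitrophenyl in place of 4-bromophenyl on a double-bonded chain carbon bound to a double-bonded chain carbon gives an at least 10-fold lower number from compound 1 to compound 4 (1.00 log units; beyond the scatter) in this assay. Within the data shown here, this place, untouched by the earlier steps, therefore also affects growth inhibition, and a group with hydrogen-bond donor and acceptors is tolerated here. The full size of the step stays unknown because compound 1 gives only a limit: the limit of > 100000 nM in this assay, at which 1 of the 4 values shown sits.

Whether the amino group, the nitro group or the pair accounts for the gain stays open. A phenyl ring carrying only an amino group or only a nitro group would separate them.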